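Swapping the Amide Substituent in a Kinase Inhibitor Series

A few compounds are considered here, and "the series" means these few. Any claim that something is new, unique, unknown or untested is made for them only; others in the source may bear on it.

Three compounds built on one shared core were tested in an assay on lysate for inhibition of 6-phosphofructo-2-kinase/fructose-2,6-bisphosphatase 3 (Homo sapiens), with stated times of 0.5 min and 45 min; a lower number here means a stronger inhibitor, a higher number a weaker inhibitor. Compound 1 `CNC(=O)c1ccncc1Nc1cc(-c2ccc3ccn(C)c3c2)c2nccnc2c1` gives 7020 nM. Compound 2 `CN1CCC(NC(=O)c2ccncc2Nc2cc(-c3ccc4ccn(C)c4c3)c3nccnc3c2)CC1` gives 19500 nM, and compound 3 `CN1CC(NC(=O)c2ccncc2Nc2cc(-c3ccc4ccn(C)c4c3)c3nccnc3c2)CCC1=O` gives 96500 nM, the highest number of the three, beyond the scatter from both others. The steps of a 2.8-fold higher number from compound 1 to compound 2 (0.44 log units; beyond the scatter) and a 14-fold higher number from compound 1 to compound 3 (1.14 log units; beyond the scatter) both run toward weaker inhibition, and a 4.9-fold higher number from compound 2 to compound 3 (0.69 log units; beyond the scatter) separates the two ring-bearing amides. Compound 4 `Cn1ccc2ccc(-c3cc(Nc4cnccc4C(=O)NCC4COCCN4)cc4nccnc34)cc21` carries (morpholin-3-yl)methyl in place of 1-methyl-6-oxopiperidin-3-yl on an amide-type nitrogen. The step of a 4.9-fold higher number from compound 2 to compound 3 (0.69 log units; beyond the scatter) bears most directly on this change, as both swap one ring for another on that nitrogen. Compound 4 is expected to recover part of that loss, an expected 2.8-fold lower number from compound 3 to compound 4 (0.44 log units; beyond the scatter). Compound 4 is therefore estimated at 35000 nM, within 10000 nM to 120000 nM.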

Compound 4, half-maximal inhibitory concentration: 41700 nM
Compound 4: middle estimate off by 1.2-fold (0.08 log units), on the low side, within the range that was stated.
By their numbers in this assay, from the lowest: compound 1; then compound 2; then compound 4; then compound 3.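

In this assay, swapping 1-methyl-6-oxopiperidin-3-yl for (morpholin-3-yl)methyl on the amide-type nitrogen wins back part of the lost inhibition, with a 2.3-fold lower number from compound 3 to compound 4 (0.36 log units; beyond the scatter) as the gain. The recovery is only partial, since a 2.1-fold higher number from compound 2 to compound 4 (0.33 log units; beyond the scatter) and a 5.9-fold higher number from compound 1 to compound 4 (0.77 log units; beyond the scatter) both remain, so among these four compounds the small methyl of compound 1 stays ahead of all three ring-bearing groups. Nothing available here explains these differences. Still open, from the compounds shown here alone, is how an open-chain group ending in an amine, such as 2-(dimethylamino)ethyl, or a plain hydrogen in place of methyl would behave on that nitrogen.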